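This account rests on a few compounds, and the source may have more. Where it says the series, first, only, none or still open, it means among the compounds named here.

Series notes, shared core with variation at one aromatic carbon.

Compound 1 `CCc1cc(C)n(C)c(=O)c1CN1CCc2c(Cl)cc(-c3c(C)noc3C)c(Cl)c2C1=O` carries ethyl at the variable position. In an assay on isolated protein for inhibition of histone-lysine N-methyltransferase EZH2 (Homo sapiens), read by filter binding, with a stated time of 1 h (on this read-out higher numbers stand for weaker inhibition and lower numbers for stronger inhibition), compound 1 gives 82 nM. Compound 2 `Cc1noc(C)c1-c1cc(Cl)c2c(c1Cl)C(=O)N(Cc1c(C3CC3)cc(C)n(C)c1=O)CC2` carries cyclopropyl in its place, and in this assay compound 2 gives 302 nM. Among the measured compounds shown here, the single step of a 3.7-fold higher number from compound 1 to compound 2 (0.57 log units; beyond the scatter) is the only measured change in the set. On the two numbers available, compound 2 stands at the higher one, with compound 1 the nearest neighbour at the lower one.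

Compound 3 `CSc1cc(C)n(C)c(=O)c1CN1CCc2c(Cl)cc(-c3c(C)noc3C)c(Cl)c2C1=O` is not yet measured. It differs from compound 2 by methylsulfanyl in place of cyclopropyl on an aromatic carbon of a six-membered aromatic ring with 1 nitrogen. For the measured compounds named here, no measured step covers a methylsulfanyl group; only the step from ethyl to cyclopropyl bears on the same position, and it showed that a small change there moves the number beyond the scatter. Given that compound 1 gives 82 nM and compound 2 gives 302 nM, the expected step for compound 3 is a 2.3-fold lower number from compound 2 to compound 3 (0.37 log units; beyond the scatter), toward the lower side. The estimated result for compound 3 in this assay is 130 nM, within 45 nM to 400 nM.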

Compound 3, half-maximal inhibitory concentration: 1.3 nM
Estimate against measurement, compound 3: 100-fold (2.00 log units) above, and the stated range ends above it.
By their numbers in this assay, from the lowest: compound 3; then compound 1; then compound 2.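

In this assay, methylsulfanyl on this aromatic carbon, opposite the ring nitrogen, gives the lowest number of the three compounds: a 230-fold lower number from compound 2 to compound 3 (2.37 log units; beyond the scatter) against cyclopropyl, and a 63-fold lower number from compound 1 to compound 3 (1.80 log units; beyond the scatter) against ethyl. Among the compounds shown here, the range of values at this one position is therefore far wider than the ethyl to cyclopropyl step alone showed, and both carbon-only groups stand on the same, higher side of compound 3, the only compound here with sulfur at this position. The data at hand offer no measurement that accounts for the size of this change.

As far as these compounds go, it remains open whether the low number of compound 3 depends on the sulfur itself or on the methylsulfanyl group as a whole; methoxy, with oxygen in place of sulfur, and ethylsulfanyl, a longer chain on the same sulfur, would test these two readings. A dimethylamino group at the same carbon would further show how narrowly the low number is tied to methylsulfanyl.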